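Swapping the Aryl Group on the Triazole Nitrogen

This account rests on a few compounds, and the source may have more. Where it says the series, first, only, none or still open, it means among the compounds named here.

Compound 1 (`N#CC1=C(N)Oc2c(c3nc4ccccc4nc3c3ccccc23)C12C(=O)N(Cc1cnnn1-c1ccc(F)cc1)c1ccccc12`) gives > 50000 nM in a functional assay on MCF7 cells (Homo sapiens) for antiproliferative activity, read by MTT assay, with a stated time of 48 h (a higher number here means a weaker inhibitor, a lower number a stronger inhibitor), which is a limit of the assay and not a number. Compound 2 (`Cc1ccc(-n2nncc2CN2C(=O)C3(C(C#N)=C(N)Oc4c3c3nc5ccccc5nc3c3ccccc43)c3ccccc32)cc1C`) gives > 50000 nM, again a limit rather than a number. Compound 3 (`CCOc1ccc(-n2nncc2CN2C(=O)C3(C(C#N)=C(N)Oc4c(N)cc5nc6ccccc6nc5c43)c3ccccc32)cc1`) gives 26800 nM.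

Going by the values given here, compound 3 therefore stands as the only compound with a measured number; the other two sit at the limit (the limit of > 50000 nM in this assay, at which 2 of the 3 values shown sit). Among the compounds with values here, the single measured step, a step that the two limits leave unreadable from compound 1 to compound 2, concerns the same aromatic nitrogen as the change studied here, but both of its ends are limits, so its size cannot be read. Compound 4 (`N#CC1=C(N)Oc2c(N)cc3nc4ccccc4nc3c2C12C(=O)N(Cc1cnnn1-c1ccc(Cl)cc1[N+](=O)[O-])c1ccccc12`) differs from compound 3 in one place: 4-chloro-2-nitrophenyl in place of 4-ethoxyphenyl on an aromatic nitrogen. Within the data shown here, no measured step reads the effect of this kind of exchange, so the data give no direction for it, and the most defensible expectation is a value close to that of compound 3. Compound 4 is therefore expected to give about 30000 nM, with a likely range from 12000 nM to 80000 nM, meaning an expected step of a 1.1-fold higher number from compound 3 to compound 4 (0.05 log units; within the scatter) that need not exceed the scatter.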

Compound 4, half-maximal inhibitory concentration: > 50000 nM
Compound 4: no number, only a limit (the forecaster's own chance of this, stated with the estimate: 35%); middle value at least 1.6-fold (0.22 log units) from the limit.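

Replacing 4-ethoxyphenyl with 4-chloro-2-nitrophenyl on the aromatic nitrogen gives, in this assay, an at least 1.8-fold higher number from compound 3 to compound 4 (0.27 log units; that floor lies within the scatter). Unlike the earlier step at this position, this one has a measured number at one end, so it can be read, but only as a floor, and it therefore suggests a weakening without establishing one. Compound 4 gives a limit and not a number, which places it with most of the compounds shown: the limit of > 50000 nM in this assay, at which 3 of the 4 values shown sit.

The compounds shown leave open whether the chlorine or the nitro group matters more in this exchange, as the two enter together and neither appears alone. They also leave open how the aryl group would read with an amine or a carboxylic acid in place of the ethoxy group.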